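The compounds below may be only part of what the source reports. "The series", "measured", "known", "first", "only" and "open" are said of these compounds alone.

In an assay on isolated protein for inhibition of Equilibrative nucleoside transporter 1 (Homo sapiens) (on this read-out higher numbers stand for weaker inhibition and lower numbers for stronger inhibition), compound 3 `OC[C@H]1O[C@@H](n2cnc3c(SCc4ccc(Cl)cc4Cl)ncnc32)[C@H](O)[C@@H]1O` gives 4.37 nM, the lowest number among the three compounds measured. Its nearest neighbour is compound 1 `N#Cc1ccc(CSc2ncnc3c2ncn3[C@@H]2O[C@H](CO)[C@@H](O)[C@H]2O)cc1`, which in this assay gives 4.57 nM, so that the step of a 1.0-fold lower number from compound 1 to compound 3 (0.02 log units; within the scatter). The furthest is compound 2 `Cc1cccc(CSc2ncnc3c2ncn3[C@@H]2O[C@H](CO)[C@@H](O)[C@H]2O)c1`, which gives 16.2 nM in this assay; the step of a 3.7-fold lower number from compound 2 to compound 3 (0.57 log units; beyond the scatter), and likewise a 3.5-fold higher number from compound 1 to compound 2 (0.55 log units; beyond the scatter).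

Compound 4 `OC[C@H]1O[C@@H](n2cnc3c(SCc4ccc(Cl)c(Cl)c4)ncnc32)[C@H](O)[C@@H]1O` is obtained from compound 3 by the change (3,4-dichlorophenyl in place of 2,4-dichlorophenyl on a saturated chain carbon bound to a sulfur); the same difference, cut one bond further out, reads 2,4-dichlorobenzyl to 3,4-dichlorobenzyl. All three measured steps exchange the aromatic group on that same saturated chain carbon bound to a sulfur, and none of them is larger than modest, while one lies within the scatter. Going by the values given here, no measured step moves a chlorine around the ring with the rest held constant. The step of a 1.4-fold higher number from compound 3 to compound 4 (0.14 log units; within the scatter) is therefore expected to stay within the scatter or to be at most modest in either direction. Compound 4 is estimated to give 6 nM in this assay, with a range from 2.5 nM to 15 nM.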

Compound 4, inhibition constant: 12.6 nM
The estimate for compound 4 lay 2.1-fold (0.32 log units) below the measured number; measured number inside the range.
By their numbers in this assay, from the lowest: compounds 3 and 1 (each within the scatter of the next); then compounds 4 and 2 (each within the scatter of the next).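

In this assay, the change to 3,4-dichlorophenyl gives a 2.9-fold higher number from compound 3 to compound 4 (0.46 log units; beyond the scatter) even though the two groups hold the same atoms, so at this position the arrangement of the two chlorines alone can move the number beyond the scatter. The same group also separates compound 4 from the 4-cyanophenyl group, with a 2.8-fold higher number from compound 1 to compound 4 (0.44 log units; beyond the scatter), but not from the 3-methylphenyl group, with a 1.3-fold lower number from compound 2 to compound 4 (0.11 log units; within the scatter), so the four compounds now fall into two pairs. Nothing available explains why the arrangement of the chlorines matters.

The compounds shown leave open how a single chlorine would read, as in 2-chlorophenyl or 4-chlorophenyl. They also leave open whether the gap between the two dichlorophenyl groups would persist with 2,4-dimethylphenyl and 3,4-dimethylphenyl, or with a longer chain between the sulfur and the ring.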